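Swapping the aryl substituent on the shared core

A few compounds are considered here, and "the series" means these few. Any claim that something is new, unique, unknown or untested is made for them only; others in the source may bear on it.

Of the compounds shown here, three built on the same core have been measured in a functional assay for agonist activity at G protein-coupled receptor 88 (Homo sapiens), read by HTRF and cAMP accumulation; a higher number here means that more compound is needed for the effect, a lower number that less compound is needed. Compound 1 `CC(C)C[C@H](N)CN(C(=O)[C@@H]1C[C@H]1c1ccccc1)c1ccc(C2=CCCC2)cc1` carries a cyclopent-1-en-1-yl group; in this assay compound 1 gives 1200 nM. Compound 2 `CC(C)C[C@H](N)CN(C(=O)[C@@H]1C[C@H]1c1ccccc1)c1ccc(C2=CCCCCC2)cc1` carries a cyclohept-1-en-1-yl group in that place, and in this assay compound 2 gives 2100 nM. Compound 3 `Cc1cccc(-c2ccc(N(C[C@@H](N)CC(C)C)C(=O)[C@@H]3C[C@H]3c3ccccc3)cc2)c1` has a 3-methylphenyl group there, and in this assay compound 3 gives 1200 nM. Compound 3 stands level with compound 1, the two together being the lowest of the three numbers; the widest gap among the three is a 1.8-fold lower number from compound 2 to compound 3 (0.24 log units; within the scatter), which is within the scatter. The remaining steps, a 1.8-fold higher number from compound 1 to compound 2 (0.24 log units; within the scatter) and no change at the digits printed from compound 1 to compound 3 (within the scatter), are likewise within the scatter. Compound 4 `COc1ccccc1-c1ccc(N(C[C@@H](N)CC(C)C)C(=O)[C@@H]2C[C@H]2c2ccccc2)cc1` is the next variation: 2-methoxyphenyl in place of 3-methylphenyl on an aromatic carbon. For the measured compounds named here, every measured step so far changes this same group, and none of them shifted this assay beyond the scatter, so the expectation for this step is again a change no larger than the scatter, which amounts to an estimated 1.3-fold higher number from compound 3 to compound 4 (0.10 log units; within the scatter). For compound 4 the expected value in this assay is 1500 nM, with a range from 500 nM to 4500 nM.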

Compound 4, half-maximal effective concentration: 3200 nM
Estimate against measurement, compound 4: 2.1-fold (0.33 log units) below; the range from low to high includes it.
By their numbers in this assay, from the lowest: compounds 1, 3, 2 and 4 (each within the scatter of the next, the first and the last beyond it).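

In this assay, this position now gives its first steps beyond the scatter (a 2.7-fold higher number from compound 3 to compound 4 (0.43 log units; beyond the scatter)) and (a 2.7-fold higher number from compound 1 to compound 4 (0.43 log units; beyond the scatter)), so the group on this aromatic carbon, para to a large group, can be changed in a way that registers in the assay, though only modestly. Compound 4 cannot be told apart from the cycloheptenyl compound (a 1.5-fold higher number from compound 2 to compound 4 (0.18 log units; within the scatter)), and the swap from 3-methylphenyl to 2-methoxyphenyl alters two things at once: it adds an oxygen, with one hydrogen-bond acceptor, and it moves the substituent to a different place on the phenyl ring. No supporting evidence is available on what lies behind the higher number for compound 4.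

The compounds shown leave open whether the oxygen or the new placing on the ring goes with the step, and a 2-methylphenyl or a 3-methoxyphenyl group at the same carbon would separate the two. They also leave open how this position responds to a phenyl ring carrying an amine or a carboxylic acid.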